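Piperazine nitrogen substituent and urotensin-2 receptor antagonism

The source may report more compounds than this note shows. Statements on the series, on what has been measured and on what is new or still open speak of the compounds shown alone.

Compound 1 `CCN1CCN(c2cccc3c2CN([C@H](CCCNS(=O)(=O)c2c[nH]cn2)c2ccc(OC)c(OC)c2)C3=O)CC1`: 51 nM
Compound 2 `COc1ccc([C@@H](CCCN(C)S(=O)(=O)c2cccs2)N2Cc3c(cccc3N3CCN(C4CC4)CC3)C2=O)cc1OC`: 1200 nM
Compound 3 `COc1ccc([C@@H](CCCN(C)S(=O)(=O)c2cccs2)N2Cc3c(cccc3N3CCN(C)CC3)C2=O)cc1OC`: 340 nM

In a functional assay on RMS13 cells for antagonist activity at Urotensin-2 receptor (Homo sapiens), read by FLIPR and calcium flux, with a stated time of 1 h (on this read-out higher numbers stand for weaker inhibition and lower numbers for stronger inhibition), compound 3 gives 340 nM, the second highest of the three numbers; compound 2 gives a higher number and compound 1 a lower one. Compound 4 `COc1ccc([C@@H](CCCN(C)S(=O)(=O)c2cccs2)N2Cc3c(cccc3N3CCNCC3)C2=O)cc1OC` differs from compound 3 by hydrogen in place of methyl on an amine nitrogen in a ring. The one measured step that bears on this place, a 3.5-fold lower number from compound 2 to compound 3 (0.55 log units; beyond the scatter), showed a modest gain on shortening the group on the ring nitrogen; whether removing the last carbon continues that trend is not shown by any pair here. Compound 4 is therefore expected to sit close to compound 3, with a step of a 1.4-fold lower number from compound 3 to compound 4 (0.13 log units; within the scatter) estimated, giving an expected value of 250 nM within a range of 80 nM to 800 nM.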

Compound 4, half-maximal inhibitory concentration: 410 nM
Compound 4: middle estimate off by 1.6-fold (0.21 log units), on the low side, within the range that was stated.
By their numbers in this assay, from the lowest: compound 1; then compounds 3 and 4 (each within the scatter of the next); then compound 2.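

In this assay, hydrogen in place of methyl on the ring nitrogen gives a 1.2-fold higher number from compound 3 to compound 4 (0.08 log units; within the scatter), so the gain seen on leaving cyclopropyl does not continue to the 4-methylpiperazin-1-yl to piperazin-1-yl change. With a 2.9-fold lower number from compound 2 to compound 4 (0.47 log units; beyond the scatter), hydrogen matches methyl in separating from cyclopropyl, which leaves compound 2 apart from both. Nothing given here accounts for this result.

Going by these compounds, whether an isopropyl or an acetyl group on this nitrogen would fall with compound 2 or with compound 3 and compound 4 remains open. Compound 1 differs from them in more than one place, so its ethyl group cannot be read against them.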